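The source may hold more compounds than are shown below. What is called first, only, known or untested is meant among the compounds shown, and "the series" means these compounds.

- Compound 1 `C#Cc1cn([C@@H]2O[C@H](CO)[C@@H](O)[C@H]2O)c2ncnc(OC)c12`: 98400 nM
- Compound 2 `CSc1ncnc2c1c(-c1ccoc1)cn2[C@@H]1O[C@H](CO)[C@@H](O)[C@H]1O`: 98800 nM
- Compound 3 `CSc1ncnc2c1c(-c1ccsc1)cn2[C@@H]1O[C@H](CO)[C@@H](O)[C@H]1O`: 95800 nM

All three compounds were tested in an ADME assay on BJ cells (Homo sapiens), read by MTT assay, with a stated time of 72 h; on this read-out lower numbers stand for stronger inhibition and higher numbers for weaker inhibition. Compound 3 sits level with compound 1 and compound 2, since every gap among the three values lies within the scatter.

Compound 4 `C#Cc1cn([C@@H]2O[C@H](CO)[C@@H](O)[C@H]2O)c2ncnc(SC)c12` has ethynyl in place of thiophen-3-yl on an aromatic carbon of the five-membered aromatic ring (ethynyl in place of thiophen-3-yl on an aromatic carbon). Going by the values given here, one measured step bears on this change. It concerns the same carbon and amounts to a 1.0-fold lower number from compound 2 to compound 3 (0.01 log units; within the scatter), which cannot be told apart from the scatter. That step only exchanges one five-membered aromatic ring for another, whereas ethynyl has no ring, so it is a loose guide. Among the compounds with values here, no measured step shows the effect of removing the ring.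

In this assay, no change beyond the scatter is therefore expected, although a lower number remains possible. The expected change is a 1.1-fold lower number from compound 3 to compound 4 (0.03 log units; within the scatter). For compound 4 the estimated value is 90000 nM, with an expected range from 30000 nM to 125000 nM.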

Compound 4, half-maximal inhibitory concentration: 68600 nM
The estimate for compound 4 lay 1.3-fold (0.12 log units) above the measured number, and the stated range covers the measured number.
By their numbers in this assay, from the lowest: compounds 4, 3, 1 and 2 (each within the scatter of the next).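

In this assay ethynyl, which has no ring, in place of thiophen-3-yl on the aromatic carbon gives a 1.4-fold lower number from compound 3 to compound 4 (0.15 log units; within the scatter) and in place of furan-3-yl gives a 1.4-fold lower number from compound 2 to compound 4 (0.16 log units; within the scatter) so removing the ring altogether at this position, and not only exchanging one ring for another, stays within the scatter. On the other aromatic carbon that differs, methylsulfanyl in place of methoxy with ethynyl kept gives a 1.4-fold lower number from compound 1 to compound 4 (0.16 log units; within the scatter) so this exchange also cannot be told apart from the scatter. Nothing measured here offers an explanation for these results.

Still open, as far as these compounds go, is whether an amine or a carboxylic acid on the carbon that carries ethynyl would shift the number beyond the scatter. The same question stands for a longer chain, such as propylsulfanyl, in place of methylsulfanyl.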